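A Fluorine Moved on a Fluorophenyl Ring: Expected Cytotoxicity

This account rests on a few compounds, and the source may have more. Where it says the series, first, only, none or still open, it means among the compounds named here.

Compound 1 `Cc1c(C(=O)Nc2ccc(Oc3ccnc4[nH]ccc34)c(F)c2)nnn1-c1ccccc1F` and compound 2 `Cc1c(C(=O)Nc2ccc(Oc3ccnc4[nH]ccc34)c(F)c2)nnn1-c1ccc(F)cc1` share one core; compound 3 `O=C(Nc1ccc(Oc2ccnc3[nH]ccc23)cc1)c1nnn(-c2ccccc2F)c1C(F)(F)F` and compound 4 `O=C(Nc1ccc(Oc2ccnc3[nH]ccc23)cc1)c1nnn(-c2ccc(F)cc2)c1C(F)(F)F` share another. How the two cores differ is not broken down here.

In a functional assay on A549 cells (Homo sapiens) for cytotoxicity, read by MTT assay, with a stated time of 72 h (on this read-out higher numbers stand for weaker inhibition and lower numbers for stronger inhibition), compound 1 gives 390 nM. Compound 2 gives 150 nM, and the change 4-fluorophenyl in place of 2-fluorophenyl on an aromatic nitrogen made a step of a 2.6-fold lower number from compound 1 to compound 2 (0.41 log units; beyond the scatter) in this assay. Compound 3 gives 210 nM, which sits within the scatter of both compound 1 and compound 2.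

Compound 4 carries the change (4-fluorophenyl in place of 2-fluorophenyl on an aromatic nitrogen). Within the data shown here, this is the same kind of change as the one from compound 1 to compound 2, not the same change: in compound 1 the place is next to the ring atom that bears a methyl group, while in compound 3 it is next to the ring atom that bears a trifluoromethyl group.

Because compound 1 to compound 2 gave a 2.6-fold lower number from compound 1 to compound 2 (0.41 log units; beyond the scatter), a step of a similar size is expected from compound 3 to compound 4, estimated as a 2.1-fold lower number from compound 3 to compound 4 (0.32 log units; beyond the scatter) in this assay. This expectation rests on a single measured pair, so the spread around it is kept wide. Compound 4 is expected to give about 100 nM in this assay, with a range from 45 nM to 230 nM.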

Compound 4, half-maximal inhibitory concentration: 180 nM
Compound 4: the middle estimate sits 1.8-fold (0.26 log units) below what was measured; the range from low to high includes it.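

In this assay, putting 4-fluorophenyl in place of 2-fluorophenyl on the core of compound 3 gave a 1.2-fold lower number from compound 3 to compound 4 (0.07 log units; within the scatter), so on this core the swap has no effect that can be told apart from ordinary variation between repeat measurements. Set beside the earlier step, the results on the two cores cannot be told apart either: the same change on two cores in this assay, a 2.6-fold lower number (0.41 log units; beyond the scatter) from compound 1 to compound 2 and a 1.2-fold lower number (0.07 log units; within the scatter) from compound 3 to compound 4, 2.2-fold (0.35 log units) apart, within the scatter of two such steps. Among these compounds, the data therefore give no sign that the core changes the outcome of this swap, but they do not prove that it carries over, as they rest on only two pairs, and only one of those steps stands clear of the scatter.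

All the compounds shown carry a fluorophenyl group on the aromatic nitrogen, so it remains open what a plain phenyl, a chlorophenyl or a methoxyphenyl group would do there. As far as these compounds go, it also remains open whether the same swap would behave in the same way on a core with an ethyl group in place of the methyl or trifluoromethyl group.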